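The source may report more compounds than this note shows. Statements on the series, on what has been measured and on what is new or still open speak of the compounds shown alone.

The measured compounds:
compound 1 `COc1ccc([C@@H]2CC(=O)c3c(O)cc(OCc4cn(Cc5ccccc5C#N)nn4)cc3O2)cc1O` with 14600 nM
compound 2 `COc1ccc([C@@H]2C/C(=N\O)c3c(O)cc(OCc4cn(C5CCCC5)nn4)cc3O2)cc1O` with 6880 nM
compound 3 `COc1ccc([C@@H]2C/C(=N\O)c3c(O)cc(OCc4cn(-c5ccccc5)nn4)cc3O2)cc1O` with 6130 nM

All three were tested in a functional assay on RAW264.7 cells (Mus musculus) for inhibition, read by Griess assay, with stated times of 2 h and 24 h; a lower number here means a stronger inhibitor, a higher number a weaker inhibitor. Compound 1 gives the highest number of the three; compound 2 stands nearest to it and compound 3 furthest from it, and both gaps lie beyond the scatter. Compounds 2 and 3 differ from compound 1 elsewhere in the shared core as well as on the aromatic nitrogen, and between themselves only in the substituent on that nitrogen; the step of a 1.1-fold lower number from compound 2 to compound 3 (0.05 log units; within the scatter) stays within the scatter.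

Compound 4 `COc1ccc([C@@H]2CC(=O)c3c(O)cc(OCc4cn(Cc5cccc(C(F)(F)F)c5)nn4)cc3O2)cc1O` has not yet been measured. It differs from compound 1 in one place: 3-(trifluoromethyl)phenyl in place of 2-cyanophenyl on a saturated chain carbon bound to an aromatic nitrogen. For the measured compounds named here, no measured pair changes exactly this part of the molecule. Going by the values given here, the only measured step that touches the substituent on the aromatic nitrogen is a 1.1-fold lower number from compound 2 to compound 3 (0.05 log units; within the scatter), and it is within the scatter; it gives no reason to expect a large shift from exchanging one substituted phenyl ring for another on the saturated chain carbon. The expected step of a 1.2-fold lower number from compound 1 to compound 4 (0.09 log units; within the scatter) therefore does not go beyond the scatter. Compound 4 is expected to give 12000 nM in this assay, within a range from 5000 nM to 30000 nM.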

Compound 4, half-maximal inhibitory concentration: 19900 nM
For compound 4 the middle estimate is 1.7-fold (0.22 log units) below the measured one; low and high end bracket the measured number.
By their numbers in this assay, from the lowest: compounds 3 and 2 (each within the scatter of the next); then compounds 1 and 4 (each within the scatter of the next).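

In this assay, exchanging 2-cyanophenyl for 3-(trifluoromethyl)phenyl on a saturated chain carbon bound to an aromatic nitrogen gives a 1.4-fold higher number from compound 1 to compound 4 (0.13 log units; within the scatter), so the two substituted rings cannot be told apart at this place on the core of compound 1. For the compounds shown here, this is the first step that changes the group on this saturated chain carbon, and it replaces both the substituent and its printed location on the ring, from 2-cyano to 3-(trifluoromethyl), without moving the number beyond the scatter; the earlier step, a 1.1-fold lower number from compound 2 to compound 3 (0.05 log units; within the scatter), exchanged cyclopentyl for phenyl directly on the aromatic nitrogen and on a different core. No measurement shown here bears on why compound 1 and compound 4 read alike.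

The compounds shown leave open whether a ring carrying an amine or a carboxylic acid, or a longer chain in place of the single saturated chain carbon, would shift the number beyond the scatter. They also leave open whether the 2-cyanobenzyl to 3-(trifluoromethyl)benzyl exchange would give a similar step on the core shared by compound 2 and compound 3.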